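Trifluoromethyl removal from compound 3: working notes

The source may hold more compounds than are shown below. What is called first, only, known or untested is meant among the compounds shown, and "the series" means these compounds.

- Compound 1 `O=C(CCCCC(S)CCS)Nc1ccccc1`: 13.7%
- Compound 2 `O=C(CCCCC(S)CCS)Nc1ccc(Cl)cc1`: 21.3%
- Compound 3 `O=C(CCCCC(S)CCS)Nc1ccc([N+](=O)[O-])c(C(F)(F)F)c1`: 92.7%

In a functional assay on HO8910 cells (Homo sapiens) for inhibition, read by MTT assay, with a stated time of 24 h, tested at 100 ug/mL (a lower number here means less inhibition of growth, a higher number more inhibition of growth at the concentration tested), compound 3 gives 92.7%, the highest of the three numbers and beyond the scatter from both others. Compound 4 `O=C(CCCCC(S)CCS)Nc1ccc([N+](=O)[O-])cc1` differs from it as follows: hydrogen in place of trifluoromethyl on an aromatic carbon. For the measured compounds named here, the one measured step, a number 7.6 percentage points higher from compound 1 to compound 2 (within the scatter), lies within the scatter and involves chloro, so it bears only loosely on this change. Going by the values given here, no measured compound carries the nitro group without trifluoromethyl, so the size of the step is poorly defined. A drop is expected, given as a number 37.7 percentage points lower from compound 3 to compound 4 (beyond the scatter). For compound 4 the estimate is 55%, with an expected range from 25% to 90%.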

Compound 4, percent growth inhibition at one concentration: 51.2%
The estimate for compound 4 lay 3.8 percentage points above the measured number, and the stated range covers the measured number.
By their numbers in this assay, from the lowest: compounds 1 and 2 (each within the scatter of the next); then compound 4; then compound 3.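

In this assay the trifluoromethyl group ortho to a nitro group matters: hydrogen in its place gives a number 41.5 percentage points lower from compound 3 to compound 4 (beyond the scatter) and removes the top number in the series. The nitro group still counts without it: a number 37.5 percentage points higher from compound 1 to compound 4 (beyond the scatter) comes with nitro in place of hydrogen, and a number 29.9 percentage points higher from compound 2 to compound 4 (beyond the scatter) with nitro in place of chloro. No evidence at hand gives a reason for these steps.

Open, from the compounds shown here alone, is whether trifluoromethyl without the nitro group would lift the number over that of compound 1. Also open, going by these compounds, is whether a nitrile or an amine in the trifluoromethyl place would hold the level of compound 3.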